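Amino to Hydroxy on the Shared Core: Cytotoxicity Outlook

The source may report more compounds than this note shows. Statements on the series, on what has been measured and on what is new or still open speak of the compounds shown alone.

Compound 1, `O=c1[nH]c(Nc2cc(F)cc(F)c2)nc2cc([N+](=O)[O-])ccc12`: > 25000 nM
Compound 2, `Nc1ccc2c(=O)[nH]c(Nc3cc(F)cc(F)c3)nc2c1`: > 25000 nM

Both measurements come from an ADME assay on Vero cells (Chlorocebus sabaeus) for cytotoxicity, read by WST assay; on this read-out higher numbers stand for lower toxicity in this test and lower numbers for higher toxicity in this test. For compound 1 the reading > 25000 nM is a limit of the assay, not a number. For compound 2 the reading > 25000 nM is likewise a limit. Going by the values given here, the only measured step, a step that the two limits leave unreadable from compound 1 to compound 2, therefore has no readable size, since both compounds sit at the limit of > 25000 nM in this assay, at which 2 of the 2 values shown sit. On the numbers shown, compound 2 stands at the limit of this assay and no closer figure is known for it.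

Compound 3, `O=c1[nH]c(Nc2cc(F)cc(F)c2)nc2cc(O)ccc12`, has not yet been measured in this assay. It differs from compound 2 by hydroxy in place of amino on an aromatic carbon. Among the compounds with values here, the one measured step bears on this change only loosely: it too swapped one small group for another on an aromatic carbon of the shared core, and it left both compounds at the limit. No step beyond the scatter is therefore expected in this assay. Compound 3 is expected to give about 40000 nM in this assay. Its expected range runs from 15000 nM to 100000 nM, most probably again reported only as a limit. The expected step is a step that the limit leaves unreadable from compound 2 to compound 3.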

Compound 3, half-maximal cytotoxic concentration: > 25000 nM
Compound 3 gave a limit, no number; the forecaster's own chance of this, stated with the estimate: 80%; the middle value does not contradict the limit.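

Compound 3, like compound 1 and compound 2, gives only a limit in this assay, not a number, so its steps from compound 1 and compound 2 cannot be read: the limit of > 25000 nM in this assay, at which 3 of the 3 values shown sit.

The compounds shown leave open how the nitro, amino and hydroxy compounds would rank against one another if each had an exact number.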